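The compounds below may be only part of what the source reports. "The series", "measured", "known", "first", "only" and "open" are said of these compounds alone.

In an assay (Rattus norvegicus) for inhibition of Fatty-acid amide hydrolase 1 (Homo sapiens) (a lower number here means a stronger inhibitor, a higher number a weaker inhibitor), compound 3 `CNC(=O)c1cnc(C(=O)CCCCCCc2ccccc2)o1` gives 7 nM. Compound 1 `NC(=O)c1cccc(-c2cnc(C(=O)CCCCCCc3ccccc3)o2)c1` gives 6 nM in this assay, and the two differ only by a 1.2-fold higher number from compound 1 to compound 3 (0.07 log units; within the scatter), so they sit together. Compound 2 `O=C(O)c1ccc(-c2cnc(C(=O)CCCCCCc3ccccc3)o2)cc1` gives 60 nM, and the step of an 8.6-fold lower number from compound 2 to compound 3 (0.93 log units; beyond the scatter) places compound 3 clearly apart from compound 2. Among the three numbers, compound 3 therefore stands with compound 1 and well away from compound 2.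

Compound 4 `O=C(CCCCCCc1ccccc1)c1ncc(C(=O)N2CCOCC2)o1` differs from compound 3 in one place: morpholin-4-yl in place of methylamino on a carbonyl carbon. Among the measured compounds shown here, no measured step alters this amide by itself. The two steps that touch the same side of the shared core, a 1.2-fold higher number from compound 1 to compound 3 (0.07 log units; within the scatter) and an 8.6-fold lower number from compound 2 to compound 3 (0.93 log units; beyond the scatter), show that exchanging the whole group there can leave the number nearly unchanged or shift it modestly. A small step is expected in this assay, most likely a slightly higher number. Compound 4 is therefore estimated at 15 nM, with a range from 4 nM to 60 nM. The expected step of a 2.1-fold higher number from compound 3 to compound 4 (0.33 log units; beyond the scatter) would stay close to the usual scatter.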

Compound 4, inhibition constant: 24 nM
Estimate against measurement, compound 4: 1.6-fold (0.20 log units) below; low and high end bracket the measured number.
By their numbers in this assay, from the lowest: compounds 1 and 3 (each within the scatter of the next); then compound 4; then compound 2.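

Among the compounds shown here, compound 4 is the first compound here in which only the group on this carbonyl carbon changes. Replacing methylamino with morpholin-4-yl adds a six-membered ring, removes the one hydrogen-bond donor and gives a 3.4-fold higher number from compound 3 to compound 4 (0.54 log units; beyond the scatter) in this assay, so the amide is sensitive to this exchange. Against the two phenyl-bearing compounds, the (morpholin-4-yl)carbonyl group gives a 4.0-fold higher number from compound 1 to compound 4 (0.60 log units; beyond the scatter) but also a 2.5-fold lower number from compound 2 to compound 4 (0.40 log units; beyond the scatter), which places compound 4 in the gap between them. Nothing measured here explains why the number rises.

As far as these compounds go, it remains open whether the ring, the missing amide hydrogen or the ring oxygen drives this step. A piperidin-1-yl group would keep the ring without that oxygen, and dimethylamino would drop the amide hydrogen without any ring.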